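The compounds below may be only part of what the source reports. "The series", "measured", "known", "first", "only" and "open" are said of these compounds alone.

Measured so far in a functional assay on HT-29 cells (Homo sapiens) for inhibition, read by MTT assay, with a stated time of 2 days; on this read-out lower numbers stand for stronger inhibition and higher numbers for weaker inhibition:

- compound 1, `Oc1ccc(/C=C/c2cccc(O)c2)cc1`: 6.9 ug/mL
- compound 2, `COc1cccc(/C=C/c2cccc(O)c2)c1`: 11.5 ug/mL
- compound 3, `Nc1ccc(/C=C/c2cccc(O)c2)cc1`: 42 ug/mL

Compound 1 and compound 2 sit close together in this assay; their values lie within the usual scatter of each other, so no order between them is drawn. The difference between the two cores of compound 1 and compound 2 is not broken down here. Compound 3 stands apart: the step of a 6.1-fold higher number from compound 1 to compound 3 (0.78 log units; beyond the scatter) is beyond the scatter, and the change behind it is amino in place of hydroxy on an aromatic carbon.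

The unmeasured compound 4, `COc1cccc(/C=C/c2cccc(N)c2)c1`, is made from compound 2 by amino in place of hydroxy on an aromatic carbon. Going by the values given here, this is the same kind of change as the one from compound 1 to compound 3, not the same: in compound 3 the new group sits para to a group of 9 heavy atoms, whereas in compound 4 it sits meta to a large group. Among the compounds with values here, only one example of the change is measured, so the size of its effect at a new place rests on a single step.

Compound 4 is expected to give a weaker number than compound 2, because the step of a 6.1-fold higher number from compound 1 to compound 3 (0.78 log units; beyond the scatter) shows a clear loss on the same kind of exchange. The step that this estimate means is expected to be a 4.8-fold higher number from compound 2 to compound 4 (0.68 log units; beyond the scatter), similar in direction to the measured one, with wide uncertainty given the different place. Compound 4 is therefore estimated at 55 ug/mL, between 18 ug/mL and 160 ug/mL.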

Compound 4, half-maximal inhibitory concentration: 19.6 ug/mL
For compound 4 the middle estimate is 2.8-fold (0.45 log units) above the measured one, within the range that was stated.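

In this assay amino in place of hydroxy on an aromatic carbon gives a 1.7-fold higher number from compound 2 to compound 4 (0.23 log units; within the scatter) and so leaves compound 2 and compound 4 without an order on this core. The clear loss seen on the core of compound 1 therefore cannot be taken as a fixed cost of this change when it is carried to another core in the series, although nothing here shows that the change is harmless in general. With only one step on each core, and with the cores and the places of the exchange both differing, the data do not separate which of these goes with the gap, and they show only that the two steps do not agree in size: the same change on two cores in this assay, a 6.1-fold higher number (0.78 log units; beyond the scatter) from compound 1 to compound 3 and a 1.7-fold higher number (0.23 log units; within the scatter) from compound 2 to compound 4, 3.6-fold (0.55 log units) apart, beyond the scatter of two such steps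

The compounds shown leave open whether a methylamino group, an acetamide or a carboxylic acid in place of the hydroxy would follow the step seen on the core of compound 1 or the one seen on the core of compound 2. Also open, on these data alone, is how the same exchange would read on further cores, for example one carrying a fluorine or a longer ether chain in place of the methoxy group.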